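A Methoxy Swap on the Urea-Bearing Ring

A few compounds are considered here, and "the series" means these few. Any claim that something is new, unique, unknown or untested is made for them only; others in the source may bear on it.

Compound 1 `O=C(Nc1nc2ccc(Oc3ccc(F)c(NC(=O)C4(c5cccc(C(F)(F)F)c5)CC4)c3)cc2s1)C1CC1`: > 20000 nM
Compound 2 `Cc1cccc(NC(=O)Nc2cc(Oc3ccc4nc(NC(=O)C5CC5)sc4c3)ccc2F)c1`: 580 nM
Compound 3 `CCOC(=O)c1cccc(NC(=O)Nc2cc(Oc3ccc4nc(NC(=O)C5CC5)sc4c3)ccc2F)c1`: 7740 nM

Of the compounds shown here, three have been tested in a functional assay on HT-29 cells (Homo sapiens) for inhibition, read by luminescence and CellTiter-Glo, with a stated time of 12 h; on this read-out lower numbers stand for an effect already at smaller amounts and higher numbers for an effect only at larger amounts of compound. Compound 1 gives only a limit of the assay, > 20000 nM, so no number stands for it. Compound 2 gives 580 nM, the lowest of the two numbers shown; its nearest neighbour is compound 3 with 7740 nM. These two differ in one place, ethoxycarbonyl in place of methyl on an aromatic carbon, and that change brought a 13-fold higher number from compound 2 to compound 3 (1.13 log units; beyond the scatter).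

Compound 4 `COc1cccc(NC(=O)Nc2cc(Oc3ccc4nc(NC(=O)C5CC5)sc4c3)ccc2F)c1` has not yet been measured. It differs from compound 2 in one place: methoxy in place of methyl on an aromatic carbon. Among the measured compounds shown here, the only measured step at this position is the one from compound 2 to compound 3, where a different group entered in place of the same methyl and the number rose sharply. A methoxy is a smaller departure from methyl than an ethoxycarbonyl, so a more modest shift, if any, is expected, possibly within the scatter. Compound 4 is therefore expected to give about 900 nM, in a range from 300 nM to 3000 nM. This corresponds to an expected step of a 1.6-fold higher number from compound 2 to compound 4 (0.19 log units; within the scatter).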

Compound 4, half-maximal effective concentration: 1370 nM
Estimate against measurement, compound 4: 1.5-fold (0.18 log units) below; the range from low to high includes it.
By their numbers in this assay, from the lowest: compound 2; then compound 4; then compound 3. At a limit, above all of these: compound 1.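

In this assay the same aromatic carbon now carries three different groups, so this position can be read as a short series instead of a single swap. Methoxy in place of methyl, a change that adds only one oxygen to the group, brought a 2.4-fold higher number from compound 2 to compound 4 (0.37 log units; beyond the scatter) and so even this small edit registers at this position, although the step is far smaller than the one seen with ethoxycarbonyl. Methoxy in place of ethoxycarbonyl brought a 5.6-fold lower number from compound 3 to compound 4 (0.75 log units; beyond the scatter) and this places compound 4 between the other two, with the methyl of compound 2 still giving the lowest number of the three.

The compounds shown leave open how a chlorine, an amine, a carboxylic acid or a longer chain such as ethyl would fare on this carbon, and whether the same order of groups would hold on the other carbons of this ring. Nothing shown here gives a reason for the order of these three groups.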